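The compounds below may be only part of what the source reports. "The series", "measured", "known", "first", "only" and "open" are said of these compounds alone.

The measured compounds and their values:

compound 1, `COc1ccc(CN(C(C)=O)c2cc(OC)c(OC)c(OC)c2)cc1O`, 270 nM
compound 2, `COc1ccc(CNc2cc(OC)c(OC)c(OC)c2)cc1Br`, 48100 nM
compound 3, `COc1cc(NCc2ccc(Br)cc2)cc(OC)c1OC`, limit only

The three compounds were tested in a functional assay on HCT-116 cells (Homo sapiens) for inhibition, read by MTT assay, with a stated time of 48 h; a lower number here means a stronger inhibitor, a higher number a weaker inhibitor. Of the two numbers obtained, compound 1 has the lowest, with 270 nM. Compound 2 is the nearest to it, and its value of 48100 nM lies far higher, well beyond the scatter of the method. Compound 3 gave no number at all in this assay but only a limit, > 80000 nM, as described by the limit of > 80000 nM in this assay, at which 1 of the 3 values shown sits. The account now follows the step from compound 1 to an untested relative, compound 4, `COc1ccc(CN(C(=O)CCCl)c2cc(OC)c(OC)c(OC)c2)cc1O`. The change is small and sits on the acyl group: chloromethyl in place of hydrogen on a saturated chain carbon bound to a carbonyl carbon. In other words the acetyl becomes a (2-chloroethyl)carbonyl, while the rest of the shared core of compound 1 is untouched. For the measured compounds named here, no step between measured compounds tells how such a change plays out in this assay. A modest step is expected, in either direction, and quite possibly none beyond the scatter, so compound 4 is estimated at 300 nM, somewhere between 80 nM and 1500 nM. That estimate means an expected step from compound 1 to compound 4 of a 1.1-fold higher number from compound 1 to compound 4 (0.05 log units; within the scatter).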

Compound 4, half-maximal inhibitory concentration: 150 nM
Beside the measured number, compound 4's estimate is 2.0-fold (0.30 log units) above it; measured number inside the range.
By their numbers in this assay, from the lowest: compounds 4 and 1 (each within the scatter of the next); then compound 2. At a limit, above all of these: compound 3.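

In this assay, for the compounds shown here, the measurement gives the first step between measured compounds that differ in one place, and it reads a 1.8-fold lower number from compound 1 to compound 4 (0.26 log units; within the scatter), so compound 1 and compound 4 cannot be told apart. Going by these compounds alone, this shows what the earlier compounds could not: on the saturated chain carbon bound to a carbonyl carbon, chloromethyl can stand in place of hydrogen, turning acetyl into (2-chloroethyl)carbonyl, while the number stays within the scatter of that of compound 1. Nothing measured here accounts for this result, and the one limit on record concerns a compound outside this step.

From the compounds shown here alone, whether the same chain carbon would tolerate other groups, such as an amine, a carboxylic acid or a longer chain, remains open. Also open, going by these compounds, is whether a propionyl group, which is the same chain without its chlorine, would read alike in this assay, and so whether the chlorine plays any part at all in the number of compound 4.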